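A few compounds are considered here, and "the series" means these few. Any claim that something is new, unique, unknown or untested is made for them only; others in the source may bear on it.

Of the compounds shown here, three of a shared core have been measured in a functional assay on the whole organism with Scenedesmus acutus as the target, read by spectrophotometry; on this read-out higher numbers stand for weaker inhibition and lower numbers for stronger inhibition. Compound 1 `S=c1n(-c2ccccc2)c(=S)n2n1CCCC2` gives 6310 nM. Compound 2 `S=c1s/c(=N\c2ccc(Cl)cc2)n2n1CCCC2` gives 234 nM. Compound 3 `C#CCOc1cc(/N=c2\sc(=S)n3n2CCCC3)c(F)cc1Cl` gives 5.5 nM, the lowest of the three numbers, beyond the scatter of both others: compound 2 stands nearest, compound 1 furthest.

Compound 4 `Fc1cc(Cl)ccc1/N=c1\sc(=S)n2n1CCCC2` has not yet been measured. It differs from compound 3 in one place: hydrogen in place of propargyloxy on an aromatic carbon. The change sits on the aromatic carbon that is ortho to a chloro group and para to a fluoro group.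

Compound 2, which carries only a chloro group on that ring, stands far from compound 3, so the propargyloxy group seems to matter a good deal, though compound 2 and compound 4 differ in the fluoro group as well. The step from compound 3 to compound 4 is expected to be an increase in this assay, beyond the scatter, estimated at an 18-fold higher number from compound 3 to compound 4 (1.26 log units; beyond the scatter). Compound 4 is therefore estimated at 100 nM, within a range from 20 nM to 500 nM.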

Compound 4, half-maximal inhibitory concentration: 67.6 nM
The estimate for compound 4 lay 1.5-fold (0.17 log units) above the measured number; low and high end bracket the measured number.
By their numbers in this assay, from the lowest: compound 3; then compound 4; then compound 2; then compound 1.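

In this assay, putting hydrogen in place of propargyloxy on the aromatic carbon ortho to a chloro group and para to a fluoro group gives a 12-fold higher number from compound 3 to compound 4 (1.09 log units; beyond the scatter), so this large step can now be assigned to that one position, without the fluoro difference mixed in. The fluoro group has a separate and smaller step, with fluoro in place of hydrogen giving a 3.5-fold lower number from compound 2 to compound 4 (0.54 log units; beyond the scatter), so the earlier gap between the chloro-only compound and the propargyloxy compound reflects two changes of different size. Nothing available explains why either change moves the number as it does.

The compounds shown leave open which part of propargyloxy matters: the triple bond, the oxygen or the length of the chain. A propoxy group, which keeps the oxygen and chain length without the triple bond, or a simple methoxy group at the same position could help separate these parts.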